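The source may report more compounds than this note shows. Statements on the series, on what has been measured and on what is new or still open speak of the compounds shown alone.

Measured so far in a functional assay on MKN-74 cells (Homo sapiens) for antiproliferative activity, with a stated time of 24 h; on this read-out higher numbers stand for weaker inhibition and lower numbers for stronger inhibition:
- compound 1, `NC(=O)c1c(NC(=O)c2ccccc2Cl)sc2c1CCN(C(=O)Nc1ccccc1Cl)C2`: 16300 nM
- compound 2, `NC(=O)c1c(NC(=O)c2ccccc2F)sc2c1CCN(C(=O)Nc1ccccc1Cl)C2`: 49600 nM
- compound 3, `NC(=O)c1c(NC(=O)c2ccccc2Br)sc2c1CCN(C(=S)Nc1ccccc1Cl)C2`: 12900 nM

Compound 1 and compound 2 differ in one place: fluoro in place of chloro on an aromatic carbon. That step reads a 3.0-fold higher number from compound 1 to compound 2 (0.48 log units; beyond the scatter). Compound 3 shares its core with neither exactly; the difference between the core of compound 3 and the core of compound 1 is not broken down here, and the two values stand within the scatter of each other.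

Compound 4, `NC(=O)c1c(NC(=O)c2ccccc2Br)sc2c1CCN(C(=S)Nc1ccccc1F)C2`, is not yet measured. From compound 3 it differs by fluoro in place of chloro on an aromatic carbon. The place is the same in both pairs, on an aromatic carbon of a six-membered aromatic ring of carbon only, ortho to a large group; read one bond further out the first pair concerns ((2-chlorophenyl)carbonyl)amino, the second (2-chlorophenyl)amino, so this is the same kind of change on a different arm. The step is expected to be a 2.7-fold higher number from compound 3 to compound 4 (0.43 log units; beyond the scatter) because the matching change gave a 3.0-fold higher number from compound 1 to compound 2 (0.48 log units; beyond the scatter). Compound 4 is estimated at 35000 nM, with a range from 14000 nM to 90000 nM.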

Compound 4, half-maximal inhibitory concentration: > 50000 nM
Compound 4 ended at the assay's limit; the forecaster's own chance of this, stated with the estimate: 10%; at least 1.4-fold (0.15 log units) between middle value and limit.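

In this assay, fluoro in place of chloro on the (2-chlorophenyl)amino arm gives an at least 3.8-fold higher number from compound 3 to compound 4 (0.58 log units; beyond the scatter), which points the same way as the same change on the ((2-chlorophenyl)carbonyl)amino arm, a 3.0-fold higher number from compound 1 to compound 2 (0.48 log units; beyond the scatter). Compound 4 stands at a limit of the assay, > 50000 nM, and not at a number. These two pairs show the direction carrying from one core to the other, but they do not show whether the size carries: the same change on two cores in this assay, a 3.0-fold higher number (0.48 log units; beyond the scatter) from compound 1 to compound 2 and an at least 3.8-fold higher number (0.58 log units; beyond the scatter) from compound 3 to compound 4; the limit leaves it open whether they differ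

Still open, going by these compounds, is whether a methyl or methoxy group in place of the chloro on the (2-chlorophenyl)amino arm would follow the same direction. Also open, on these data alone, is the size of the step in a pair with both values clear of the limit.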